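From Methoxyphenyl to Thiophene: Expecting the Half-Life

A few compounds are considered here, and "the series" means these few. Any claim that something is new, unique, unknown or untested is made for them only; others in the source may bear on it.

Within the data shown here, compound 1 `COc1ccc(CNC(=O)N2C(=O)c3ccccc3S2(=O)=O)cc1` is the one compound here with a full number in a physicochemical assay for pharmacokinetics; on this read-out higher numbers stand for a longer-lived compound and lower numbers for a shorter-lived compound; in this assay compound 1 gives 0.187 h. Compound 2 `O=C(OCc1ccccc1)N1C(=O)c2ccccc2S1(=O)=O` returns only a limit of the assay in this assay, namely < 0.0167 h, and this is the limit of < 0.0167 h in this assay, at which 1 of the 2 values shown sits. Compound 3 `O=C(NCc1cccs1)N1C(=O)c2ccccc2S1(=O)=O` differs from compound 1 in one place: thiophen-2-yl in place of 4-methoxyphenyl on a saturated chain carbon bound to an amide-type nitrogen. Among the measured compounds shown here, no measured pair shows how such a swap plays out, so the expected step of a 1.2-fold lower number from compound 1 to compound 3 (0.10 log units; within the scatter) is small, no larger than the usual scatter. Compound 3 is therefore estimated at 0.15 h, most likely between 0.05 h and 0.45 h.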

Compound 3, half-life: 0.365 h
Compound 3: middle estimate off by 2.4-fold (0.39 log units), on the low side, and the stated range covers the measured number.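

In this assay, among these compounds, the only measured swap at this position is a 2.0-fold higher number from compound 1 to compound 3 (0.29 log units; within the scatter) and so gives a first real reading for this change. On a saturated chain carbon bound to an amide-type nitrogen, the five-membered thiophen-2-yl ring can take the place of 4-methoxyphenyl without a step beyond the scatter. Nothing measured here accounts for the size of this step. Still open, as far as these compounds go, is how a different group at this place, such as a pyridine ring, an amine or a longer chain, would fare. Also open, from the compounds shown here alone, is whether the same swap would give a similar step on another core.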